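Ring-opened and cyclic analogues: single chloro removal

The compounds below may be only part of what the source reports. "The series", "measured", "known", "first", "only" and "open" are said of these compounds alone.

Measured compounds in a functional assay on the whole organism (Central nervous system) with Mus musculus as the target; on this read-out higher numbers stand for an effect only at larger amounts of compound and lower numbers for an effect already at smaller amounts:
compound 1 `O=C1CCC2(c3ccccc3)OCCCN12`: 150 mg/kg
compound 2 `O=C1CCC2(c3ccc(Cl)cc3)OCCCN12`: 81.2 mg/kg
compound 3 `O=C(CCC(=O)c1ccc(Cl)c(Cl)c1)NCCCO`: 500 mg/kg

Compound 1 and compound 2 share one core and differ by hydrogen in place of chloro on an aromatic carbon. The step of a 1.8-fold higher number from compound 2 to compound 1 (0.27 log units; within the scatter) is within the scatter, so nothing is read into the order of the two. Compound 3 stands at the highest number of the three; against compound 1 and compound 2 its values show a gap that is beyond the scatter. How the core of compound 3 differs from the core of compound 2 is not broken down here.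

Compound 4 `O=C(CCC(=O)c1ccc(Cl)cc1)NCCCO` is not yet measured in this assay. It arises from compound 3 by hydrogen in place of chloro on an aromatic carbon. This is the same kind of change as that from compound 2 to compound 1, but the place is not the same word for word: in compound 2 the chloro is para to a large group, whereas in compound 3 it is ortho to a chloro group (1 heavy atom) and meta to a large group. Among the compounds with values here, the expected step of a 1.5-fold higher number from compound 3 to compound 4 (0.18 log units; within the scatter) rests on a 1.8-fold higher number from compound 2 to compound 1 (0.27 log units; within the scatter), the only measured instance of the change, and is expected to be of similar size; the estimate carries a wide range since the surroundings of the place differ. For compound 4 the estimated value is 750 mg/kg, expected between 350 mg/kg and 1600 mg/kg.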

Compound 4, dose for half-maximal effect: 325 mg/kg
The estimate for compound 4 lay 2.3-fold (0.36 log units) above the measured number; measured number below the stated range.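

In this assay hydrogen in place of chloro on an aromatic carbon gives a 1.5-fold lower number from compound 3 to compound 4 (0.19 log units; within the scatter) and, set beside the earlier case, the change does not carry over from one core to the other as a step of fixed size or direction: the same change on two cores in this assay, a 1.8-fold higher number (0.27 log units; within the scatter) from compound 2 to compound 1 and a 1.5-fold lower number (0.19 log units; within the scatter) from compound 3 to compound 4, 2.8-fold (0.45 log units) apart, beyond the scatter of two such steps

Each step read alone lies within the scatter, so only the gap between them carries weight, and that gap rests on a single pair per core. The two cases also differ in the place of the change, which in compound 3 is ortho to a chloro group and meta to a large group, so these numbers do not separate the role of the core from that of the place.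

Still open, on these data alone, is how the open-chain core behaves with no chloro on the aromatic ring, or with fluoro or methoxy there instead. Also open, as far as these compounds go, is whether an amine or a carboxylic acid in place of the chain-end hydroxyl of compound 4 would shift the number in this assay at all.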